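Antiproliferative screen on Vero cells: N-alkyl sulfonamide variation

This account rests on a few compounds, and the source may have more. Where it says the series, first, only, none or still open, it means among the compounds named here.

Measured compounds:
compound 1 `CN(c1ccccc1Cl)S(=O)(=O)C1CC2OC1C(c1ccc(NC(=O)CCCCCCC(=O)O)cc1)=C2c1ccc(O)cc1` gives > 100000 nM in an ADME assay on Vero cells (Chlorocebus sabaeus) for antiproliferative activity, read by MTT assay, with a stated time of 72 h; on this read-out lower numbers stand for stronger inhibition and higher numbers for weaker inhibition
compound 2 `CCN(c1ccc(O)cc1)S(=O)(=O)C1CC2OC1C(c1ccc(NC(=O)CCCCCCC(=O)O)cc1)=C2c1ccc(O)cc1` gives > 100000 nM in this assay

The value shown for compound 1 in this assay is a limit of the assay, not a number. The value shown for compound 2 in this assay is likewise a limit. The step from compound 1 to compound 2 a step that the two limits leave unreadable from compound 1 to compound 2 cannot be sized, because of the limit of > 100000 nM in this assay, at which 2 of the 2 values shown sit.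

Compound 3 `CCN(c1ccccc1Cl)S(=O)(=O)C1CC2OC1C(c1ccc(NC(=O)CCCCCCC(=O)O)cc1)=C2c1ccc(O)cc1` is not yet measured in this assay. It differs from compound 1 by methyl in place of hydrogen on a saturated chain carbon bound to a sulfonamide nitrogen.

No measured step bears directly on this change: the only step shown, from compound 1 to compound 2, concerns a different part of the sulfonamide nitrogen substituent and is unreadable. Both values shown sit at the same limit, so the series gives no measured number from which a direction could be read. The expectation for compound 3 is therefore that it too will be reported at the limit, with an estimated step of a number no higher from compound 1 to compound 3 (the limit leaves the size open) that is not beyond the scatter. Compound 3 is estimated at 100000 nM in this assay, in the range 40000 nM to 300000 nM.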

Compound 3, half-maximal inhibitory concentration: > 100000 nM
Compound 3: only a limit was reported; the forecaster's own chance of this, stated with the estimate: 85%; the middle value sits exactly at the limit.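

No step can be read between compound 3 and either compound 1 or compound 2 in this assay, because all three compounds sit at the same assay limit: the limit of > 100000 nM in this assay, at which 3 of the 3 values shown sit.

The compounds shown leave open whether any change in the groups on the sulfonamide nitrogen shifts antiproliferative activity at all, and in which direction.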